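Replacing Cyclopropyl While Keeping the Fluoro Group

The source may hold more compounds than are shown below. What is called first, only, known or untested is meant among the compounds shown, and "the series" means these compounds.

Among the measured compounds shown here, in an ADME assay on Vero cells (Chlorocebus sabaeus) for cytotoxicity, read by CellTiter-Glo, with a stated time of 72 h (a higher number here means that more compound is tolerated, a lower number that less compound is tolerated), compound 3 (`[O-][n+]1nc(NC2CC2)[n+]([O-])c2ccc(F)cc21`) gives 1.3 ug/mL which is the lowest of the three numbers measured so far. Compound 1 (`[O-][n+]1nc(NC2CC2)[n+]([O-])c2ccccc21`) gives 21 ug/mL and compound 2 (`CCCC(C)Nc1n[n+]([O-])c2ccccc2[n+]1[O-]`) gives 26 ug/mL so compound 3 lies well under both. Compound 4 (`[O-][n+]1nc(N[C@@H]2C[C@H]3CC[C@@H]2C3)[n+]([O-])c2ccc(F)cc21`) differs from compound 3 by a group of 7 heavy atoms (7 carbon; 2 five-membered non-aromatic rings of carbon only) in place of a group of 3 heavy atoms (3 carbon; one three-membered non-aromatic ring of carbon only), on a nitrogen on an aromatic ring and has not yet been measured.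

For the measured compounds named here, the one measured change at that nitrogen, 1-methylbutyl in place of cyclopropyl, gave a 1.2-fold higher number from compound 1 to compound 2 (0.09 log units; within the scatter) but it was made without the fluoro group, and no group with two rings has been measured. Fluoro in place of hydrogen on an aromatic carbon gave a 16-fold lower number from compound 1 to compound 3 (1.21 log units; beyond the scatter) yet compound 4 keeps that fluoro, so this large step does not bear directly on the new change. No shift beyond the scatter is therefore expected, and the estimated step is a 1.1-fold higher number from compound 3 to compound 4 (0.03 log units; within the scatter) in this assay for this exchange. The value estimated for compound 4 is 1.4 ug/mL with an expected range of 0.5 ug/mL to 4 ug/mL in this measurement.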

Compound 4, half-maximal cytotoxic concentration: < 2.5 ug/mL
Compound 4: no number, only a limit; the forecaster's own chance of this, stated with the estimate: 5%; the middle value lies beyond the limit too.
By their numbers in this assay, from the lowest: compound 3; then compounds 1 and 2 (each within the scatter of the next).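

In this assay compound 4 gives < 2.5 ug/mL, which is a limit and not a number, so no step from compound 3 to compound 4 can be read: the limit of < 2.5 ug/mL in this assay, at which 1 of the 4 values shown sits.

What the compounds shown leave open is whether compound 4 truly differs from compound 3 in this assay, and in which direction.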